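This account rests on a few compounds, and the source may have more. Where it says the series, first, only, none or still open, it means among the compounds named here.

Working notes on the series. Compound 1 `COc1cccc(Sc2c(NS(=O)(=O)c3ccc(C(C)(C)C)cc3)noc2CCCC#N)c1` has been tested in an assay on A7R5 cells for displacement of a labelled ligand from Endothelin-1 receptor (Rattus norvegicus); a lower number here means a stronger inhibitor, a higher number a weaker inhibitor; compound 1 gives 1300 nM. Compound 2 `COc1cccc(Sc2c(NS(=O)(=O)c3ccc(C(C)(C)C)cc3)noc2CCC/C=N/O)c1` is the second member, and in this assay compound 2 gives 1500 nM. The step of a 1.2-fold higher number from compound 1 to compound 2 (0.06 log units; within the scatter) touches only the end of the chain. Compound 2 holds the highest of the two numbers seen so far, yet its gap to compound 1 lies within the scatter, so no order between the two can be read from these figures.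

Compound 3 `COc1cccc(Sc2c(NS(=O)(=O)c3ccc(C(C)(C)C)cc3)noc2CCO)c1` is the next member. The change is one oxygen atom in place of a group of 4 heavy atoms (2 carbon, 1 nitrogen, 1 oxygen; no ring), on a saturated chain carbon, two bonds along the chain from an aromatic carbon: the chain is cut back to a hydroxy on a saturated chain carbon, two bonds along the chain from an aromatic carbon. Among the compounds with values here, only the step of a 1.2-fold higher number from compound 1 to compound 2 (0.06 log units; within the scatter) bears on this change; it altered the same chain end and stayed within the scatter, which suggests that the tail tolerates change, but no measured step removes chain atoms, so the truncation itself is untested. The step expected in this assay is a 1.3-fold higher number from compound 2 to compound 3 (0.12 log units; within the scatter), modest and not clearly beyond the scatter. Compound 3 is therefore estimated at 2000 nM, with a range from 700 nM to 6000 nM.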

Compound 3, half-maximal inhibitory concentration: 770 nM
Compound 3: the middle estimate sits 2.6-fold (0.41 log units) above what was measured, and the stated range covers the measured number.
By their numbers in this assay, from the lowest: compounds 3, 1 and 2 (each within the scatter of the next).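

In this assay the chain end can now be cut back as well as altered: a 1.9-fold lower number from compound 2 to compound 3 (0.29 log units; within the scatter) is a step that removes chain atoms and still stays within the scatter. The same holds for hydroxy in place of cyanomethyl, where a 1.7-fold lower number from compound 1 to compound 3 (0.23 log units; within the scatter) is also within the scatter, so neither the group of 4 heavy atoms nor the cyanomethyl can be shown to matter at this place, on a saturated chain carbon, two bonds along the chain from an aromatic carbon, and no order among the three compounds can be read. No independent measurement accompanies these numbers to account for them.

The compounds shown leave open how an amine or a carboxylic acid on this saturated chain carbon would read in this assay, and whether a much longer chain would give a step beyond the scatter. All three share the core of compound 1, so they also leave open how much of the binding number depends on the rest of the molecule rather than on this chain.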